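Swapping a nitro for a fluoro on the outer ring

The compounds below may be only part of what the source reports. "The series", "measured", "known", "first", "only" and "open" are said of these compounds alone.

Of the compounds shown here, three sharing one core have been tested in a functional assay on HCT-116 cells (Homo sapiens) for antiproliferative activity, read by CCK-8 assay, with a stated time of 72 h; on this read-out higher numbers stand for weaker inhibition and lower numbers for stronger inhibition. Compound 1 `Nc1ccccc1NC(=O)c1ccc(COc2ccc([N+](=O)[O-])cc2)cc1` gives in this assay > 32000 nM, which is a limit of the assay rather than a number. Compound 2 `Nc1ccccc1NC(=O)c1ccc(COc2ccc(Br)cc2)cc1` likewise gives in this assay > 32000 nM, again a limit. Compound 3 `Nc1ccccc1NC(=O)c1ccc(COc2ccccc2)cc1` gives in this assay 4890 nM. The step that the two limits leave unreadable from compound 1 to compound 2 cannot be read, as both values sit at the limit (the limit of > 32000 nM in this assay, at which 2 of the 3 values shown sit). The step of an at least 6.5-fold lower number from compound 1 to compound 3 (0.81 log units; beyond the scatter) and the step of an at least 6.5-fold lower number from compound 2 to compound 3 (0.81 log units; beyond the scatter) both show that removing the substituent on the outer ring lowers the number. Compound 4 `Nc1ccccc1NC(=O)c1ccc(COc2ccc(F)cc2)cc1` has not yet been measured; it differs from compound 1 by fluoro in place of nitro on an aromatic carbon. The measured steps show that a hydrogen at this place gives a clearly lower number than either nitro or bromo, while a bromo in place of nitro leaves the value at the limit. A fluoro is a halogen like bromo yet far smaller, so a value in between seems likely. Compound 4 is therefore expected to give about 15000 nM, with a range of 5000 nM to 40000 nM. This expectation corresponds to an estimated step of an at least 2.1-fold lower number from compound 1 to compound 4 (0.32 log units; beyond the scatter).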

Compound 4, half-maximal inhibitory concentration: 3860 nM
Beside the measured number, compound 4's estimate is 3.9-fold (0.59 log units) above it; the whole stated range lies above it.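

In this assay, fluoro in place of bromo gives an at least 8.2-fold lower number from compound 2 to compound 4 (0.91 log units; beyond the scatter), so two halogens at this place on the outer ring do not read alike. Fluoro in place of nitro gives an at least 8.2-fold lower number from compound 1 to compound 4 (0.91 log units; beyond the scatter), while fluoro in place of hydrogen gives a 1.3-fold lower number from compound 3 to compound 4 (0.10 log units; within the scatter), which leaves compound 4 level with compound 3 and apart from the nitro and bromo compounds. The first and second of these steps start from a limit of the assay and not from a number: the limit of > 32000 nM in this assay, at which 2 of the 4 values shown sit.

The compounds shown leave open whether a chloro or a methyl group at this place would read like fluoro and hydrogen or like bromo and nitro. As far as these compounds go, how a methoxy group or an amine would read here also remains open.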